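The source may hold more compounds than are shown below. What is called first, only, known or untested is meant among the compounds shown, and "the series" means these compounds.

In an ADME assay on microsomes from liver (Homo sapiens) for metabolic stability, with a stated time of 30 min (on this read-out lower numbers stand for a less stable compound and higher numbers for a more stable compound), compound 1 `COC(=O)N[C@@H](CO)C(=O)O` gives 43%. Compound 2 `NC(=O)C(=O)N[C@@H](CO)C(=O)O` offers no number to start from, since the entry for compound 2 reads "not determined" (no result reported). Compound 3 `O=C(N[C@@H](CO)C(=O)O)C1CC1` differs from it by a single change, (cyclopropyl in place of carbamoyl on a carbonyl carbon), which puts cyclopropyl in place of carbamoyl on a carbonyl carbon. Among the compounds with values here, no measured step shows what such a change does in this assay, so no shift beyond the scatter is expected, and the only anchor is compound 1 at 43%. Compound 3 is expected to give 50%, with an estimated range of 25% to 80%.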

Compound 3, percent of the compound remaining: 26%
For compound 3 the middle estimate is 24 percentage points above the measured one; the range from low to high includes it.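

Cyclopropyl in place of methoxy on a carbonyl carbon gives a number 17 percentage points lower from compound 1 to compound 3 (beyond the scatter) in this assay, the first sign that the group on this carbonyl carbon can move the read-out. The step involving compound 2 cannot be read, as compound 2 has no number. Nothing shown explains why the value falls.

Still open, as far as these compounds go, is how carbamoyl itself compares with methoxy or cyclopropyl in this assay. Also open, from the compounds shown here alone, is whether an amine or a longer chain on this carbonyl carbon would stand nearer to compound 1 or to compound 3.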